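This account rests on a few compounds, and the source may have more. Where it says the series, first, only, none or still open, it means among the compounds named here.

Measured so far: compound 1 `O=C(NC1CCCCC1)Oc1cccc(-c2cccc(OC(=O)NC3CCCCC3)c2)c1`, which in an assay on cell membranes for binding affinity to Fatty-acid amide hydrolase 1 (Rattus norvegicus) (a lower number here means a stronger inhibitor, a higher number a weaker inhibitor), gives 361 nM; compound 2 `O=C(NC1CCCCC1)Oc1cccc(-c2cccc(-c3ccccc3)c2)c1`, which in this assay gives 565 nM; compound 3 `O=C(NC1CCCCC1)Oc1cccc(-c2cccc(CO)c2)c1`, which in this assay gives 8.67 nM.

Compound 3 stands lowest of the three numbers. The step of a 42-fold lower number from compound 1 to compound 3 (1.62 log units; beyond the scatter) and the step of a 65-fold lower number from compound 2 to compound 3 (1.81 log units; beyond the scatter) are both large and beyond the scatter, so compound 3 is the strongest inhibitor shown. Compound 4 `O=C(NC1CCCCC1)Oc1cccc(-c2cccc(CCO)c2)c1` differs from compound 3 by hydroxymethyl in place of hydroxy on a saturated chain carbon bound to an aromatic carbon. Among the measured compounds shown here, no measured step is of this kind: the two steps leading to compound 3 both exchange a large group for hydroxymethyl, whereas this change merely lengthens that group, hydroxymethyl to 2-hydroxyethyl. A step of no more than the scatter is therefore expected in this assay. For compound 4 a value near 14 nM is estimated, between 5 nM and 45 nM. This estimate means an expected step of a 1.6-fold higher number from compound 3 to compound 4 (0.21 log units; within the scatter).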

Compound 4, half-maximal inhibitory concentration: 18.7 nM
Estimate against measurement, compound 4: 1.3-fold (0.13 log units) below, and the stated range covers the measured number.
By their numbers in this assay, from the lowest: compound 3; then compound 4; then compounds 1 and 2 (each within the scatter of the next).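

In this assay, lengthening hydroxymethyl to 2-hydroxyethyl gives a 2.2-fold higher number from compound 3 to compound 4 (0.33 log units; beyond the scatter), so a modest but readable price is attached to this extension on the shared core. The advantage over the larger groups nonetheless survives, with a 30-fold lower number from compound 2 to compound 4 (1.48 log units; beyond the scatter) and a 19-fold lower number from compound 1 to compound 4 (1.29 log units; beyond the scatter), so low numbers at this position are not confined to hydroxymethyl. Nothing given here accounts for the difference between the two chains. On these data alone, whether a longer chain such as 3-hydroxypropyl would raise the number further remains open, as does whether an amine or a carboxylic acid in place of the hydroxy would keep it low.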